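Sigma-1 binding series: chloro on the pendant phenyl

A few compounds are considered here, and "the series" means these few. Any claim that something is new, unique, unknown or untested is made for them only; others in the source may bear on it.

Measured so far:
compound 1, `O=c1cc(-c2ccccc2)oc2ccc(OCCCCCCN3CCC(O)CC3)cc12`, 121 nM
compound 2, `O=c1cc(-c2ccccc2)oc2ccc(OCCCCCCN3CCNC(CCO)C3)cc12`, 94 nM

Both compounds were read in an assay on isolated protein (Cavia porcellus) with Sigma non-opioid intracellular receptor 1 (Homo sapiens) as the target, read by radioligand binding; a higher number here means a weaker inhibitor, a lower number a stronger inhibitor. Compound 1 gives 121 nM and compound 2 gives 94 nM; the two numbers sit within the scatter of one another, so compound 1 is not separated from compound 2 by this assay. Within the data shown here, the one step available, a 1.3-fold lower number from compound 1 to compound 2 (0.11 log units; within the scatter), changes only the amine at the far end of the six-carbon chain and says nothing about the phenyl ring.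

Compound 3, `O=c1cc(-c2ccccc2Cl)oc2ccc(OCCCCCCN3CCC(O)CC3)cc12`, is compound 1 with chloro in place of hydrogen on an aromatic carbon. Among the measured compounds shown here, no measured pair touches that ring, so there is no step that bears on this change; the amine step from compound 1 to compound 2 is the only comparison in hand and is unrelated. The expectation therefore rests on compound 1 alone: a number near 121 nM is expected, with a wide range in either direction, and no step beyond the scatter is assumed.

For compound 3 in this assay the estimate is 100 nM (range 35 nM to 300 nM), which is expected to amount to a 1.2-fold lower number from compound 1 to compound 3 (0.08 log units; within the scatter).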

Compound 3, half-maximal inhibitory concentration: 29 nM
Beside the measured number, compound 3's estimate is 3.4-fold (0.54 log units) above it; the measured number lies below the stated range.
By their numbers in this assay, from the lowest: compound 3; then compounds 2 and 1 (each within the scatter of the next).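

Among these compounds, until now the only step lay at the amine end of the chain and stayed within the scatter, so nothing showed whether the phenyl ring mattered in this assay. Among the compounds shown here, replacing hydrogen with chloro on an aromatic carbon, ortho to a large group, gives a 4.2-fold lower number from compound 1 to compound 3 (0.62 log units; beyond the scatter) and so is the first change to separate two compounds, showing that this ring position is sensitive to a substituent of a single heavy atom. No measurement at hand accounts for the size or direction of this step.

Going by these compounds, the finding rests on one matched pair, so it remains open whether a fluoro, bromo, methyl or methoxy group in the same place would give a similar step, or whether the effect is specific to chloro. On these data alone, it also remains open whether the 2-chlorophenyl change would carry over to the 3-(2-hydroxyethyl)piperazin-1-yl amine of compound 2, or to a chain shorter or longer than the six-carbon one.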